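From Anilide to Acid on a Shared Core

The compounds below may be only part of what the source reports. "The series", "measured", "known", "first", "only" and "open" are said of these compounds alone.

Three measured compounds share one core and differ only at the far end of the chain. Compound 1 `COc1cc(/C=C/C(=O)Nc2ccccc2)ccc1OCCCCCCN1CCCCC1` gives 1.77 in a physicochemical assay for lipophilicity, using the shake flask method, measured as octanol-water partition, at pH 7.4 (a higher number here means a more lipophilic compound, a lower number a more polar compound), the lowest of the three numbers, though both neighbours sit within the scatter of it. Compound 2 `COc1cc(/C=C/C(=O)Nc2ccccc2)ccc1OCCCCCCCCCCN(C)C` gives 1.8, and compound 3 `CCN(CC)CCCCCCCCCCOc1ccc(/C=C/C(=O)Nc2ccccc2)cc1OC` gives 1.83. The steps of a number 0.03 log units higher from compound 1 to compound 2 (within the scatter), a number 0.06 log units higher from compound 1 to compound 3 (within the scatter) and a number 0.03 log units higher from compound 2 to compound 3 (within the scatter) all concern exchanges of the amine on the chain, and none of them moves the number beyond the scatter.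

Compound 4 `COc1cc(/C=C/C(=O)O)ccc1OCCCCCCN1CCCCC1` is not yet measured. It differs from compound 1 at the other end of the molecule: hydroxy in place of anilino on a carbonyl carbon. Going by the values given here, no measured step touches this carbonyl position, so the three amine steps do not bear on it directly; they only show that the chain end tolerates small changes without moving this assay. The change itself removes an aromatic ring and six carbons and leaves a single oxygen in their place, which is a far larger alteration than any of the measured ones.

Compound 4 is therefore expected to sit clearly lower, with a step of a number 1.77 log units lower from compound 1 to compound 4 (beyond the scatter) from compound 1. The estimate for compound 4 is 0, within a range from -1 to 0.9.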

Compound 4, partition coefficient: 1.32
Estimate against measurement, compound 4: 1.32 log units below; measured number outside the range, above it.
By their numbers in this assay, from the lowest: compound 4; then compounds 1, 2 and 3 (each within the scatter of the next).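

Going by these compounds alone, the carbonyl position is the first place where this assay moves beyond the scatter: hydroxy in place of anilino on a carbonyl carbon gives a number 0.45 log units lower from compound 1 to compound 4 (beyond the scatter), whereas every amine exchange at the far end of the chain stayed within it. The step is nonetheless modest for a change in which anilino, with 7 heavy atoms and one six-membered aromatic ring of carbon only, gives way to hydroxy, with 1 heavy atom, so this position can respond to the exchange without the number falling far. Nothing in the material shown accounts for the size of this step.

With only this one exchange at the carbonyl carbon, the compounds shown leave open how much of the step follows the loss of anilino and how much the arrival of hydroxy, a question that a methyl ester or a primary amide at the same place would address. Also open, from the compounds shown here alone, is whether the carboxylic acid counterparts of compound 2 and compound 3, with their longer chains, would show a step of similar size.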